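This account rests on a few compounds, and the source may have more. Where it says the series, first, only, none or still open, it means among the compounds named here.

Measured compounds:
Compound 1, `Cc1cc(O)c(C(=O)/C=C/c2ccc(OCc3ccccc3)cc2)c(-c2ccccc2)c1C(=O)/C=C/c1ccc(OCc2ccccc2)cc1`, gives 10000 nM in a functional assay on MDA-MB-231 cells (Homo sapiens) for cytotoxicity, read by MTT assay, with a stated time of 24 h; on this read-out lower numbers stand for stronger inhibition and higher numbers for weaker inhibition.
Compound 2, `COc1ccc(/C=C/C(=O)c2c(C)cc(O)c(C(=O)/C=C/c3ccc(OC)c(OC)c3)c2-c2ccccc2)cc1OC`, is recorded in this assay as "not active" (no number reported), with no single number.
Compound 3, `Cc1cc(O)c(C(=O)/C=C/c2ccc(OCc3ccccc3)cc2)c(-c2ccc(OCc3ccccc3)cc2)c1C(=O)/C=C/c1ccc(OCc2ccccc2)cc1`, gives 20000 nM in this assay.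

Compound 1 and compound 3 share one core, and compound 3 carries benzyloxy in place of hydrogen on an aromatic carbon. That change gave a 2.0-fold higher number from compound 1 to compound 3 (0.30 log units; within the scatter), so on the evidence of these two compounds the added benzyloxy group left the cytotoxic reading essentially where it was.

Compound 2 rests on a different core, and the difference between the two cores is not broken down here. Compound 4, `COc1ccc(/C=C/C(=O)c2c(C)cc(O)c(C(=O)/C=C/c3ccc(OC)c(OC)c3)c2-c2ccc(OCc3ccccc3)cc2)cc1OC`, has not yet been measured. It stands to compound 2 as compound 3 stands to compound 1: it carries benzyloxy in place of hydrogen on an aromatic carbon. The place of the change is described in the same words in both pairs, so this is the same change made once more, on the other core.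

The expectation for compound 4 therefore rests on two things: compound 2 showed no measurable activity, and the same benzyloxy addition in the first pair moved the reading by only a 2.0-fold higher number from compound 1 to compound 3 (0.30 log units; within the scatter). If that step carries over, compound 4 is expected to remain without useful cytotoxicity, and it may well be reported again only as inactive rather than with a number. As a working estimate, compound 4 is expected to give about 40000 nM in this assay, with a plausible range from 10000 nM to 200000 nM should a number be obtained.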

Compound 4, half-maximal inhibitory concentration: 22000 nM
Beside the measured number, compound 4's estimate is 1.8-fold (0.26 log units) above it; the measured number falls inside the stated range.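

Within the data shown here, compound 2 is recorded without a number in this assay, so no step from compound 2 to compound 4 can be read, although compound 4 gives 22000 nM there. The compounds shown leave open whether adding benzyloxy to the core of compound 2 moves the reading at all. No measurement shown here offers an explanation for these readings.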